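The source may hold more compounds than are shown below. What is called first, only, known or untested is meant among the compounds shown, and "the series" means these compounds.

Compound 3 `CC(C)OC(=O)C1=CCCCC1S(=O)(=O)Cc1ccc(F)cc1Cl` gives 100 nM in a functional assay on RAW264.7 cells (Mus musculus), read by fluorescence (a higher number here means a weaker inhibitor, a lower number a stronger inhibitor), the higher of the two single numbers in this assay; compound 2 `CCOC(=O)C1=CCCCC1S(=O)(=O)Cc1ccc(F)cc1F` gives 14 nM, a gap beyond the scatter, while compound 1 `CCOC(=O)C1=CCCCC1S(=O)(=O)Cc1ccc(F)cc1Cl` gives 10 nM; 10000 nM; 5.7 nM (3 entries), values that spread widely, as the several entries of compound 1 in this assay, 10 nM; 10000 nM; 5.7 nM (3 entries) shows. Compound 4 `CC(=O)OCC1=CCCCC1S(=O)(=O)Cc1ccc(F)cc1Cl` differs from compound 3 by one change: acetoxymethyl in place of isopropoxycarbonyl on a double-bonded ring carbon, an acetoxymethyl in place of isopropoxycarbonyl on a double-bonded ring carbon. No comparable step has been measured among these compounds, so the expectation rests only on the values of compound 3. A small weakening, near the edge of the scatter, is expected, a 2.0-fold higher number from compound 3 to compound 4 (0.30 log units; within the scatter). Compound 4 is estimated at 200 nM, within a range of 40 nM to 1500 nM.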

Compound 4, half-maximal inhibitory concentration: > 10000 nM
Compound 4 gave a limit, no number (the forecaster's own chance of this, stated with the estimate: 10%); middle value at least 50-fold (1.69 log units) away from the limit.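

In this assay, acetoxymethyl in place of isopropoxycarbonyl on the double-bonded ring carbon gives an at least 100-fold higher number from compound 3 to compound 4 (2.00 log units; beyond the scatter), so this position does not accept every oxygen-bearing group, although both groups count the same hydrogen-bond acceptors. Compound 4 gives > 10000 nM, which is a limit of the assay and not a number. A single high reading here needs caution, as one entry of compound 1 also lies far from its other two: the several entries of compound 1 in this assay, 10 nM; 10000 nM; 5.7 nM (3 entries)

Going by these compounds, what remains open is whether the carbonyl attached directly to the ring carbon is what matters. A carboxylic acid, an amide or a hydroxymethyl at this place would help to separate these possibilities.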